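This account rests on a few compounds, and the source may have more. Where it says the series, first, only, none or still open, it means among the compounds named here.

In a functional assay on K562 cells (Homo sapiens) for antiproliferative activity, read by MTT assay, with a stated time of 48 h (on this read-out lower numbers stand for stronger inhibition and higher numbers for weaker inhibition), compound 1 (`COc1ccc(-c2ccc3c(c2)C(=O)C(=O)N3Cc2ccc(OC)c(OC)c2)cc1`) gives 60 nM, compound 2 (`COc1ccc(-c2ccc3c(c2)C(=O)C(=O)N3Cc2ccc(C#N)cc2)cc1`) gives 380 nM and compound 3 (`COc1ccc(CN2C(=O)C(=O)c3cc(-c4cc(OC)cc(OC)c4)ccc32)cc1`) gives 510 nM. Compound 3 therefore lies within the scatter of compound 2 and well above compound 1. Compound 4 (`COc1ccc(CN2C(=O)C(=O)c3cc(-c4ccc(F)c(Cl)c4)ccc32)cc1`) carries 3-chloro-4-fluorophenyl in place of the 3,5-dimethoxyphenyl of compound 3 on an aromatic carbon: 3-chloro-4-fluorophenyl in place of 3,5-dimethoxyphenyl on an aromatic carbon. Among the measured compounds shown here, the only measured step, a 6.3-fold higher number from compound 1 to compound 2 (0.80 log units; beyond the scatter), is modest and concerns a different change, on a saturated chain carbon bound to an amide-type nitrogen. For the measured compounds named here, no measured step covers this aromatic carbon, so no change beyond the scatter is expected in this assay. The expected step is a 1.5-fold lower number from compound 3 to compound 4 (0.16 log units; within the scatter). The estimate for compound 4 is 350 nM, with an expected range of 100 nM to 1200 nM.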

Compound 4, half-maximal inhibitory concentration: 380 nM
Beside the measured number, compound 4's estimate is 1.1-fold (0.04 log units) below it; measured number inside the range.
By their numbers in this assay, from the lowest: compound 1; then compounds 2, 4 and 3 (each within the scatter of the next).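

Among the compounds shown here, at this aromatic carbon, a 1.3-fold lower number from compound 3 to compound 4 (0.13 log units; within the scatter) in this assay is the first measured step, and it lies within the scatter. The aryl group here can thus lose its methoxy groups and hydrogen-bond acceptors, taking on chlorine and fluorine instead, with no change in the number beyond the scatter. Nothing available explains this result.

On these data alone, whether any group at this carbon moves the number beyond the scatter remains open. An amine or a carboxylic acid on this phenyl ring would test that.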